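Swapping a Bromophenyl for a Nitrophenyl on a Shared Core

This account rests on a few compounds, and the source may have more. Where it says the series, first, only, none or still open, it means among the compounds named here.

Compound 1, `O=C(CSc1nc(Nc2ccccc2)c2ccccc2n1)Nc1ccc([N+](=O)[O-])cc1`, gives 13000 nM in a functional assay on NCI-H1975 cells (Homo sapiens) for inhibition, read by MTT assay, with a stated time of 72 h; a lower number here means a stronger inhibitor, a higher number a weaker inhibitor.
Compound 2, `C=CC(=O)Nc1cccc(NC(=O)CSc2nc(Nc3ccccc3Br)c3ccccc3n2)c1`, gives 19300 nM in this assay.

Both measured compounds are weak inhibitors in this assay. Compound 2 has the higher of the two numbers, but its nearest neighbour, compound 1, lies within the usual scatter of it, so the two cannot be ranked against each other. Going by the values given here, no pair of measured compounds differs in only one place, so no single measured step is available to guide the next change.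

Compound 3, `C=CC(=O)Nc1cccc(NC(=O)CSc2nc(Nc3cccc([N+](=O)[O-])c3)c3ccccc3n2)c1`, is the unmeasured compound. It differs from compound 2 in one place: 3-nitrophenyl in place of 2-bromophenyl on a nitrogen on an aromatic ring. With no measured step of this kind on the shared core, the change cannot be tied to any shown number. Nothing in the two measured values points to a large move in either direction, so the step in this assay is expected to stay within the scatter: a 1.4-fold lower number from compound 2 to compound 3 (0.14 log units; within the scatter). Compound 3 is therefore estimated at 14000 nM, with a range from 5000 nM to 40000 nM.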

Compound 3, half-maximal inhibitory concentration: 22600 nM
Compound 3: middle estimate off by 1.6-fold (0.21 log units), on the low side, within the range that was stated.
By their numbers in this assay, from the lowest: compounds 1, 2 and 3 (each within the scatter of the next).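

In this assay, going by these compounds alone, this is the first step on the shared core that can be read directly: a 1.2-fold higher number from compound 2 to compound 3 (0.07 log units; within the scatter), so 2-bromophenyl and 3-nitrophenyl on this nitrogen cannot be told apart by their numbers. The two groups are quite different, since one carries a bromine and has 0 hydrogen-bond acceptors while the other carries a nitro group and has 2, yet this single exchange gives no measurable separation between compound 2 and compound 3. No independent measurement is available to explain this result.

Within the data shown here, it remains open whether any group on this ring can move the number beyond the scatter, since the two groups compared here are only one pair and both compounds remain weak inhibitors. An amine or a carboxylic acid on the phenyl ring, or a longer chain in place of the ring on this nitrogen, would test whether this position responds to change at all.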